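Glucose-derived glycogen phosphorylase inhibitors: thioglucoside step

The source may hold more compounds than are shown below. What is called first, only, known or untested is meant among the compounds shown, and "the series" means these compounds.

In an assay on isolated protein (Oryctolagus cuniculus) for inhibition of glycogen phosphorylase, brain form (Homo sapiens) (a lower number here means a stronger inhibitor, a higher number a weaker inhibitor), compound 1 `NCC1OC(CO)C(O)C(O)C1O` gives 16800000 nM; 34500000 nM (2 entries), and the repeat entries are recorded as the several entries of compound 1 in this assay, 16800000 nM; 34500000 nM (2 entries). Compound 2 `CNNC(=O)[C@H]1O[C@H](CO)[C@@H](O)[C@H](O)[C@H]1O` gives 1800000 nM in this assay; that is the only number shown for it, with one further entry carrying no single value. Within the data shown here, no step between two measured compounds is available in this assay. Compound 3 `NC(=O)CS[C@H]1O[C@H](CO)[C@@H](O)[C@H](O)[C@H]1O` carries the change ((carbamoylmethyl)sulfanyl in place of (methylamino)carbamoyl on a saturated ring carbon), (carbamoylmethyl)sulfanyl in place of (methylamino)carbamoyl on a saturated ring carbon. The step is expected to be a 2.2-fold higher number from compound 2 to compound 3 (0.35 log units; beyond the scatter), somewhat beyond the scatter toward weaker inhibition. Compound 3 is therefore estimated at 4000000 nM, in the range 1500000 nM to 12000000 nM.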

Compound 3, inhibition constant: 21100000 nM
Estimate against measurement, compound 3: 5.3-fold (0.72 log units) below; the whole stated range lies below it.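

At the ring carbon next to the ring oxygen, the exchange is far from neutral in this assay: the step is a 12-fold higher number from compound 2 to compound 3 (1.07 log units; beyond the scatter). The two groups have equal heavy-atom counts, so this position responds to the identity of the group and not to that count alone. Repeat entries at this end of the scale can spread: the several entries of compound 1 in this assay, 16800000 nM; 34500000 nM (2 entries)

Which part of the exchange carries the step remains open, whether the sulfur link or the terminal amide. A carboxylic acid or a longer chain on the sulfur would help separate these.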